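Chloro to bromo swap on two benzyl thioether cores

The source may hold more compounds than are shown below. What is called first, only, known or untested is meant among the compounds shown, and "the series" means these compounds.

Compound 1 `Clc1ccccc1CSc1nnc(-c2cnccn2)o1` and compound 2 `Brc1ccccc1CSc1nnc(-c2cnccn2)o1` share one core; compound 3 `Clc1ccc(CSc2nnc(-c3cnccn3)s2)cc1` and compound 4 `Brc1ccc(CSc2nnc(-c3cnccn3)s2)cc1` share another. The difference between the two cores is not broken down here. In a functional assay on HepG2 cells (Homo sapiens) for antiproliferative activity, read by MTT assay, with a stated time of 48 h (a lower number here means a stronger inhibitor, a higher number a weaker inhibitor), compound 1 gives 12300 nM, compound 2 gives 4220 nM, and compound 3 gives 6230 nM; compound 2 and compound 3 lie within the scatter of each other, and compound 3 and compound 1 as well.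

The change from compound 1 to compound 2 is bromo in place of chloro on an aromatic carbon. Its step is a 2.9-fold lower number from compound 1 to compound 2 (0.46 log units; beyond the scatter). The change from compound 3 to compound 4 is bromo in place of chloro on an aromatic carbon. It is the same kind of change, not the same: in compound 1 the substituent sits ortho to a large group, in compound 3 it sits para to a large group, both on an aromatic carbon of a six-membered aromatic ring of carbon only. The change occurs twice among the compounds shown, once measured.

For compound 4 in this assay a step of a 2.2-fold lower number from compound 3 to compound 4 (0.35 log units; beyond the scatter) is expected, resting on the measured pair, where the step from compound 1 to compound 2 was a 2.9-fold lower number from compound 1 to compound 2 (0.46 log units; beyond the scatter), tempered by the different place around the change and by a single supporting pair. The estimate for compound 4 in this assay is 2800 nM, with an expected range from 1000 nM to 7000 nM.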

Compound 4, half-maximal inhibitory concentration: 780 nM
For compound 4 the middle estimate is 3.6-fold (0.56 log units) above the measured one; measured number outside the range, below it.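

In this assay, bromo in place of chloro on an aromatic carbon gives a lower number on both cores, and the new pair adds an 8.0-fold lower number from compound 3 to compound 4 (0.90 log units; beyond the scatter), so the direction of the change carries from one core to the other in these two pairs. The size of the step does not carry over: the same change on two cores in this assay, a 2.9-fold lower number (0.46 log units; beyond the scatter) from compound 1 to compound 2 and an 8.0-fold lower number (0.90 log units; beyond the scatter) from compound 3 to compound 4, 2.7-fold (0.44 log units) apart, beyond the scatter of two such steps. The two pairs differ both in the core and in where the halogen sits on the six-membered ring, so they cannot show which of these two differences goes with the larger step, and two pairs give no reliable size for the change on a further core of this series.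

The compounds shown leave open how large the step would be with the halogen in one and the same place on both cores, and how much of the difference between the compounds comes from the core itself, as no pair isolates either point. Also open, going by these compounds, is whether the direction seen from chloro to bromo continues to iodo, and how a group of another kind on the same aromatic carbon, such as methoxy, an amine or a carboxylic acid, would compare.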